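Carbamate variants at the urotensin-2 receptor: a methoxyphenyl swap

The source may report more compounds than this note shows. Statements on the series, on what has been measured and on what is new or still open speak of the compounds shown alone.

Measured compounds:
- compound 1, `COc1ccc(NC(=O)OC(CCN(C)C)c2ccc(Cl)cc2)cc1`: 1660 nM
- compound 2, `CN(C)CCC(OC(=O)NCc1ccccc1)c1ccc(Cl)cc1`: 2140 nM

Both numbers come from an assay on NIH3T3 cells with Urotensin-2 receptor (Homo sapiens) as the target; on this read-out lower numbers stand for an effect already at smaller amounts and higher numbers for an effect only at larger amounts of compound. Compound 2 gives the highest of the two numbers, and its nearest neighbour is compound 1; the change a 1.3-fold higher number from compound 1 to compound 2 (0.11 log units; within the scatter) is a benzyl in place of a 4-methoxyphenyl on an amide-type nitrogen.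

Compound 3, `COc1cccc(NC(=O)OC(CCN(C)C)c2ccc(Cl)cc2)c1`, has not yet been measured in this assay. Its difference from compound 2 is 3-methoxyphenyl in place of benzyl on an amide-type nitrogen. This is the reverse of the kind of change already seen: a methoxyphenyl group returns in place of benzyl, now carrying its methoxy group at a different ring position than in compound 1. Going by the values given here, the only step that bears on it, a 1.3-fold higher number from compound 1 to compound 2 (0.11 log units; within the scatter), was small and within the scatter, so no large shift is expected in this assay from compound 2 to compound 3, perhaps a slight move toward the number of compound 1. Compound 3 is therefore estimated at 1700 nM, with a range from 700 nM to 4200 nM. The expected step is a 1.3-fold lower number from compound 2 to compound 3 (0.10 log units; within the scatter).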

Compound 3, half-maximal effective concentration: 1120 nM
The estimate for compound 3 lay 1.5-fold (0.18 log units) above the measured number; measured number inside the range.
By their numbers in this assay, from the lowest: compounds 3, 1 and 2 (each within the scatter of the next).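

In this assay, 3-methoxyphenyl in place of benzyl on the amide-type nitrogen gives a 1.9-fold lower number from compound 2 to compound 3 (0.28 log units; within the scatter) and so adds a second case in which a change at this nitrogen stays inside the usual variation between repeat measurements. The swap also brings in an oxygen and a hydrogen-bond acceptor by count, yet no effect on the number can be told apart from that variation. Moving the methoxy group, the new comparison in this series, gives a 1.5-fold lower number from compound 1 to compound 3 (0.17 log units; within the scatter) and shows that, for these two ring placements, this assay does not separate compounds with the group in one place from those with it in the other; no independent data are available to interpret these small differences.

From the compounds shown here alone, all three compounds share the same core, so the contribution of its dimethylamino group and its 4-chlorophenyl ring remains unknown. Going by these compounds, it also remains open whether a different group on the amide-type nitrogen, such as 2-methoxyphenyl, unsubstituted phenyl or a longer chain ending in a phenyl ring, would move the number by more than the usual variation.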